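Phenyl to 4-chlorophenyl in a growth inhibition series

The source may hold more compounds than are shown below. What is called first, only, known or untested is meant among the compounds shown, and "the series" means these compounds.

Values measured in a functional assay on UO-31 cells (Homo sapiens) for inhibition, with a stated time of 48 h (on this read-out higher numbers stand for weaker inhibition of growth and lower numbers for stronger inhibition of growth), are as follows.
- Compound 1 (`COc1ccccc1/C=C/C(=O)c1c(O)cc2occc2c1OC`) gives > 100000 nM as a limit of the assay
- Compound 2 (`COc1c(C(=O)/C=C/c2ccc(Cl)cc2)c(O)c(Br)c2occc12`) gives 2590 nM as a number
- Compound 3 (`C=CCc1c(O)c(C(=O)/C=C/c2ccccc2)c(OC)c2ccoc12`) gives 2890 nM as a number

Compound 3 stands within the scatter of compound 2, and the two values cannot be separated. Compound 4 (`C=CCc1c(O)c(C(=O)/C=C/c2ccc(Cl)cc2)c(OC)c2ccoc12`) is compound 3 with chloro in place of hydrogen on an aromatic carbon, para to a large group. Among the measured compounds shown here, no measured pair isolates this change. Compound 2 also carries a 4-chlorophenyl and gives 2590 nM in this assay, within the scatter of compound 3. A small expected shift toward stronger inhibition (a 1.3-fold lower number from compound 3 to compound 4 (0.12 log units; within the scatter)) may well stay within the scatter. For compound 4 the estimated value is 2200 nM with an expected range (800 nM to 6000 nM).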

Compound 4, concentration for 50% growth inhibition: 2880 nM
Compound 4: middle estimate off by 1.3-fold (0.12 log units), on the low side, and the stated range covers the measured number.
By their numbers in this assay, from the lowest: compounds 2, 4 and 3 (each within the scatter of the next). At a limit, above all of these: compound 1.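

In this assay, the phenyl to 4-chlorophenyl change gives a 1.0-fold lower number from compound 3 to compound 4 (0.00 log units; within the scatter), so this pair isolates chloro in place of hydrogen on an aromatic carbon, para to a large group, and the two values cannot be separated. Allyl in place of bromo on an aromatic carbon gives a 1.1-fold higher number from compound 2 to compound 4 (0.05 log units; within the scatter), and those two values cannot be separated either. Nothing shown offers a reason for either result.

On these data alone, it stays open whether an amine or a carboxylic acid in place of the chloro would separate from compound 4. The same holds for a longer chain in place of the allyl.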